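From a heptyl chain to a 2-methoxyethyl chain

The source may report more compounds than this note shows. Statements on the series, on what has been measured and on what is new or still open speak of the compounds shown alone.

Three compounds with a shared core and different chains on one nitrogen have been measured in a functional assay on K562 cells (Homo sapiens) for antiproliferative activity, read by CellTiter-Glo, with a stated time of 72 h; on this read-out lower numbers stand for an effect already at smaller amounts and higher numbers for an effect only at larger amounts of compound. Compound 1 `CCCCCCNc1ncnc2c1ncn2[C@@H]1O[C@H](COS(N)(=O)=O)[C@@H](O)[C@H]1O` carries hexyl and gives 160 nM. Compound 2 `CCCCCCCNc1ncnc2c1ncn2[C@@H]1O[C@H](COS(N)(=O)=O)[C@@H](O)[C@H]1O` carries heptyl and gives 132 nM. Compound 3 `CCCCCC(C)Nc1ncnc2c1ncn2[C@@H]1O[C@H](COS(N)(=O)=O)[C@@H](O)[C@H]1O` carries 1-methylhexyl and gives 203 nM. Compound 2 therefore does not stand apart from the other two.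

Compound 4 `COCCNc1ncnc2c1ncn2[C@@H]1O[C@H](COS(N)(=O)=O)[C@@H](O)[C@H]1O` changes that chain far more: methoxy in place of pentyl on a saturated chain carbon, two bonds along the chain from a nitrogen on an aromatic ring. In words, methoxy takes the place of pentyl on a saturated chain carbon, two bonds along the chain from a nitrogen on an aromatic ring, so heptyl becomes 2-methoxyethyl.

The measured steps are small: a 1.2-fold lower number from compound 1 to compound 2 (0.08 log units; within the scatter), a 1.3-fold higher number from compound 1 to compound 3 (0.10 log units; within the scatter) and a 1.5-fold higher number from compound 2 to compound 3 (0.19 log units; within the scatter). Each moves only a single methyl, however. Going by the values given here, none of the measured compounds has a chain this short or an oxygen in it, so these steps are a weak guide here. A change this much larger is expected to cost some effect in this assay, though with little certainty. The expected size is a 3.4-fold higher number from compound 2 to compound 4 (0.53 log units; beyond the scatter), towards a higher number. Compound 4 is estimated at 450 nM, with an expected range from 120 nM to 1800 nM.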

Compound 4, half-maximal effective concentration: > 1000 nM
Compound 4: only a limit was reported; the forecaster's own chance of this, stated with the estimate: 3%; at least 2.2-fold (0.34 log units) between middle value and limit.
By their numbers in this assay, from the lowest: compounds 2, 1 and 3 (each within the scatter of the next). At a limit, above all of these: compound 4.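

Compound 4 has only a limit, not a number, in this assay: the limit of > 1000 nM in this assay, at which 1 of the 4 values shown sits.

Even so, the limit is enough to place it, giving an at least 7.5-fold higher number from compound 2 to compound 4 (0.87 log units; beyond the scatter), together with an at least 6.2-fold higher number from compound 1 to compound 4 (0.79 log units; beyond the scatter) and an at least 4.9-fold higher number from compound 3 to compound 4 (0.69 log units; beyond the scatter). Going by these compounds alone, the earlier compounds showed only that hexyl, heptyl and 1-methylhexyl lie within the scatter of one another, so this is the first change on this nitrogen that clearly moves the number, and it moves it upwards. The position therefore accepts small shifts among these longer carbon chains but not every replacement, and 2-methoxyethyl is one that costs effect here.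

Compound 4 shortens the chain and brings in an oxygen in the same step, so the compounds shown cannot tell which of the two changes matters, and a plain propyl or butyl chain, without oxygen, would separate them. Also open, on these data alone, is how the number would respond to a chain longer than heptyl, or to an amine or a carboxylic acid at the end of the chain.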